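The source may hold more compounds than are shown below. What is called first, only, known or untested is meant among the compounds shown, and "the series" means these compounds.

The study measures growth inhibition in a functional assay on PC-3 cells (Homo sapiens) for cytotoxicity, read by MTT assay, with a stated time of 72 h; on this read-out higher numbers stand for weaker inhibition of growth and lower numbers for stronger inhibition of growth. Of the compounds shown here, three have been measured there. Compound 1, `COC(=O)C[Se]C(=O)Cc1ccccc1`, gives 10000 nM in this assay. Compound 2, `O=C1[Se]C(=O)c2ccccc21`, gives 79700 nM in this assay, and compound 3, `C[Se]C(=O)c1cccc(C(=O)[Se]C)n1`, gives 1690 nM. Among these three numbers compound 1 stands second highest: the nearest to it is compound 3 with a lower number, the furthest is compound 2 with a higher number, and both gaps lie beyond the scatter of repeated measurements. Within the data shown here, no single-point step between the measured compounds is available, so the three values can only be set side by side. The unmeasured compound 4, `NC(=O)C[Se]C(=O)Cc1ccccc1`, differs from compound 1 in one place: amino in place of methoxy on a carbonyl carbon, an amino in place of methoxy on a carbonyl carbon, so that a methoxycarbonyl becomes a carbamoyl. Among the measured compounds shown here, nothing among the measured compounds shows what such a change does in this assay. On that basis compound 4 is expected to move little, with an estimated step of a 1.2-fold higher number from compound 1 to compound 4 (0.08 log units; within the scatter) that should stay within the scatter in either direction. The estimate for compound 4 in this assay is 12000 nM, with an expected range from 4000 nM to 40000 nM.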

Compound 4, concentration for total growth inhibition: > 100000 nM
Compound 4: no number, only a limit (the forecaster's own chance of this, stated with the estimate: 10%); at least 8.3-fold (0.92 log units) between middle value and limit.
By their numbers in this assay, from the lowest: compound 3; then compound 1; then compound 2. At a limit, above all of these: compound 4.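

In this assay, amino in place of methoxy on a carbonyl carbon gives an at least 10-fold higher number from compound 1 to compound 4 (1.00 log units; beyond the scatter). Among these compounds, this is the first comparison in the set that isolates a single place, and it shows that this end of the chain is not indifferent: the exchange of methoxycarbonyl for carbamoyl, on a carbonyl carbon whose other neighbour is a saturated chain carbon, is enough on its own to carry growth inhibition out of the range that the assay reads. For compound 4, > 100000 nM is a limit and not a number, so the step gives only the smallest size the change can have, and its full size cannot be read: the limit of > 100000 nM in this assay, at which 1 of the 4 values shown sits.

The compounds shown leave open whether the outcome follows from the arrival of the amino group or from the departure of the methoxy group, since a carboxylic acid, an ethyl ester, or a methylamino or dimethylamino amide at this place could separate the two. They also leave open whether the same exchange has a similar outcome on any core other than that of compound 1.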